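The source may hold more compounds than are shown below. What is called first, only, known or untested is meant among the compounds shown, and "the series" means these compounds.

Measured so far in a functional assay on A549 cells (Homo sapiens) for antiproliferative activity, read by MTT assay, with a stated time of 48 h (a higher number here means a weaker inhibitor, a lower number a stronger inhibitor), in this series
Compound 1 `COc1ccc(/C=C/c2cc(OC)cc(OC)c2/C=C/C(=O)c2ccc(Cl)c(Cl)c2)cc1` gives 5.9 ug/mL in this test
Compound 2 `COc1ccc(/C=C/c2cc(OC)cc(OC)c2/C=C/C(=O)c2cccc(Br)c2)cc1` gives 8.1 ug/mL in this test
Compound 3 `COc1ccc(/C=C/c2cc(OC)cc(OC)c2/C=C/C(=O)c2ccc(Br)cc2)cc1` gives 8.3 ug/mL in this test

Compound 3 at 8.3 ug/mL sits level with the other two, since neither gap leaves the usual scatter, with a 1.0-fold higher number from compound 2 to compound 3 (0.01 log units; within the scatter) and a 1.4-fold higher number from compound 1 to compound 3 (0.15 log units; within the scatter) as the two steps.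

The next molecule, compound 4 `COc1ccc(/C=C/c2cc(OC)cc(OC)c2/C=C/C(=O)c2ccc(F)cc2)cc1`, differs from compound 3 by fluoro in place of bromo on an aromatic carbon in a single swap: fluoro in place of bromo on an aromatic carbon, para to a large group. Among the compounds with values here, no measured compound carries fluoro, so this swap has no direct precedent. The closest evidence comes from other changes on the same ring, namely a 1.0-fold higher number from compound 2 to compound 3 (0.01 log units; within the scatter) and a 1.4-fold higher number from compound 1 to compound 2 (0.14 log units; within the scatter) as well as a 1.4-fold higher number from compound 1 to compound 3 (0.15 log units; within the scatter), and all of them are small. In this assay no step beyond the scatter is therefore expected, and neither direction is favoured. The expected change is a 1.0-fold higher number from compound 3 to compound 4 (0.01 log units; within the scatter) and would be too small to read as a real difference. For compound 4 the estimated value is 8.5 ug/mL with an expected range from 4.5 ug/mL to 16 ug/mL allowing for the untested fluoro group.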

Compound 4, half-maximal inhibitory concentration: 6.6 ug/mL
The estimate for compound 4 lay 1.3-fold (0.11 log units) above the measured number, within the range that was stated.
By their numbers in this assay, from the lowest: compounds 1, 4, 2 and 3 (each within the scatter of the next).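

In this assay, within the data shown here, the ring position para to a large group accepts fluoro in place of bromo without a readable change (a 1.3-fold lower number from compound 3 to compound 4 (0.10 log units; within the scatter)), and this is the first fluoro group seen at this site. The fluoro compound also stays level with the other two halogen-bearing rings (a 1.2-fold lower number from compound 2 to compound 4 (0.09 log units; within the scatter)) and (a 1.1-fold higher number from compound 1 to compound 4 (0.05 log units; within the scatter)), so all four compounds read alike, and none can be ranked above another. Nothing measured here explains why these halogen swaps leave the number so little changed.

Every ring shown carries only halogens, so it remains open whether an amine, a carboxylic acid or a methoxy group at this position would move the number beyond the scatter. A ring with no substituent at all would also show whether the halogen matters here.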